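Halogen Position on the Pendant Ring and Clearance

The source may report more compounds than this note shows. Statements on the series, on what has been measured and on what is new or still open speak of the compounds shown alone.

compound 1, `O=S(=O)(c1cc(Cl)cc(Cl)c1)c1cnc2c(F)cccc2c1-c1ccccc1F`: 0.44 mL/min
compound 2, `O=S(=O)(c1cc(Cl)cc(Cl)c1)c1cnc2c(F)cccc2c1-c1cccc(F)c1`: 1.08 mL/min

The two measured compounds share one core and differ only in where a single fluorine sits on the pendant phenyl ring. In an ADME assay on microsomes from liver (Homo sapiens) for metabolic stability, tested at 2.5 uM (on this read-out lower numbers stand for slow clearance and higher numbers for fast clearance), compound 1 gives 0.44 mL/min, and compound 2 gives 1.08 mL/min, the higher of the two numbers. The step between them, a 2.5-fold higher number from compound 1 to compound 2 (0.39 log units; beyond the scatter), shows that moving one halogen around this ring can push the read-out beyond the usual scatter.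

Compound 3, `O=S(=O)(c1cc(Cl)cc(Cl)c1)c1cnc2c(F)cccc2c1-c1ccc(Cl)cc1`, carries the change (4-chlorophenyl in place of 3-fluorophenyl on an aromatic carbon). Among the compounds with values here, no measured step involves chlorine, so the only guide is that one repositioning of a halogen gave a 2.5-fold higher number from compound 1 to compound 2 (0.39 log units; beyond the scatter). A further modest shift in either direction, or none beyond the scatter, is plausible, and the estimate therefore sits near the value of compound 2 with a wide range around it. Compound 3 is expected to give 1.3 mL/min, with a range from 0.5 mL/min to 3.2 mL/min. The expected step is a 1.2-fold higher number from compound 2 to compound 3 (0.08 log units; within the scatter).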

Compound 3, intrinsic clearance in a liver preparation (reported as CLH), per the amount of preparation that the assay uses: 0.78 mL/min
Estimate against measurement, compound 3: 1.7-fold (0.22 log units) above, and the stated range covers the measured number.
By their numbers in this assay, from the lowest: compounds 1, 3 and 2 (each within the scatter of the next, the first and the last beyond it).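

In this assay, setting 4-chlorophenyl in place of 3-fluorophenyl on this aromatic carbon gives a 1.4-fold lower number from compound 2 to compound 3 (0.14 log units; within the scatter), and setting it in place of 2-fluorophenyl gives a 1.8-fold higher number from compound 1 to compound 3 (0.25 log units; within the scatter). The new compound therefore cannot be told apart from either fluorinated compound, even though those two differ from each other by more than the scatter, so this position can carry a different halogen at a different place on the pendant ring without a clear change in the read-out. Nothing available here accounts for these numbers.

This change swaps the halogen and moves it on the ring in a single step, so the compounds shown leave the contributions of the element and of its place on the ring unseparated; a comparison of fluorine and chlorine at the same place on the ring would be needed to pull them apart. Going by these compounds, it also remains open how clearance would respond to a pendant ring carrying something other than a halogen, such as a methoxy group, an amine or a carboxylic acid.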